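Isopropyl in place of methoxyethyl: a small expected step

This account rests on a few compounds, and the source may have more. Where it says the series, first, only, none or still open, it means among the compounds named here.

Compound 3 `COCCNc1nnc(SCC(=O)N(Cc2cccc([N+](=O)[O-])c2)c2ccc(F)cc2)s1` gives 38.6% in an assay on isolated protein for inhibition of Amine oxidase [flavin-containing] B (Homo sapiens), read by fluorescence and Amplex Red, with a stated time of 30 min, tested at 1 mM; a higher number here means a stronger effect of the compound at the concentration tested, a lower number a weaker effect. Its number sits at the low end of the three measured, yet compound 1 `CCCCNc1nnc(SCC(=O)N(Cc2cccc([N+](=O)[O-])c2)c2ccc(F)cc2)s1` at 40.6% and compound 2 `CCCNc1nnc(SCC(=O)N(Cc2cccc([N+](=O)[O-])c2)c2ccc(F)cc2)s1` at 42.7% both lie within the scatter of it. Compound 4 `CC(C)Nc1nnc(SCC(=O)N(Cc2cccc([N+](=O)[O-])c2)c2ccc(F)cc2)s1` differs from compound 3 by isopropyl in place of 2-methoxyethyl on a nitrogen on an aromatic ring. Among the compounds with values here, three measured steps bear on this, each changing the same chain on the same nitrogen: a number 2.1 percentage points higher from compound 1 to compound 2 (within the scatter), a number 2 percentage points lower from compound 1 to compound 3 (within the scatter) and a number 4.1 percentage points lower from compound 2 to compound 3 (within the scatter). None of these moved the inhibition beyond the scatter, so this change is not expected to either. Compound 4 is therefore estimated to give 40%, between 30% and 50%. That estimate means a step of a number 1.4 percentage points higher from compound 3 to compound 4 (within the scatter), expected to stay within the scatter.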

Compound 4, a percentage reported as inhibition, at one concentration (the size of the read-out at that concentration, not a potency): 36%
Beside the measured number, compound 4's estimate is 4 percentage points above it, and the stated range covers the measured number.
By their numbers in this assay, from the lowest: compounds 4, 3, 1 and 2 (each within the scatter of the next).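

The branched isopropyl differs in shape from the straight chains on this nitrogen, yet it stays within the scatter of all of them in this assay: a number 2.6 percentage points lower from compound 3 to compound 4 (within the scatter), a number 6.7 percentage points lower from compound 2 to compound 4 (within the scatter) and a number 4.6 percentage points lower from compound 1 to compound 4 (within the scatter). Among these four compounds, branching, like chain length and the ether oxygen, leaves the inhibition unchanged within the scatter. No available data explain why these numbers stay so close. Going by these compounds, it remains open whether a cyclohexyl ring or a chain ending in a carboxylic acid on this nitrogen would move the inhibition beyond the scatter.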